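Putting the Triple Bond Back Against the Ring Carbon

The compounds below may be only part of what the source reports. "The series", "measured", "known", "first", "only" and "open" are said of these compounds alone.

Compound 1 `CCC#C[C@@]1(O)[C@@H](CO)O[C@@H](n2ccc(N)nc2=O)[C@@H]1O` is the strongest of the three measured analogues; in a functional assay on KB cells (Homo sapiens), read by MTT assay (a higher number here means a weaker inhibitor, a lower number a stronger inhibitor), compound 1 gives 108000 nM. Compound 2 `CC[C@@]1(O)[C@@H](CO)O[C@@H](n2ccc(N)nc2=O)[C@@H]1O` gives 258000 nM in this assay, a step of a 2.4-fold higher number from compound 1 to compound 2 (0.38 log units; beyond the scatter). Compound 3 `C#CC[C@@]1(O)[C@@H](CO)O[C@@H](n2ccc(N)nc2=O)[C@@H]1O` gives > 350000 nM in this assay, which is only a limit of the assay, sitting at the limit of > 350000 nM in this assay, at which 1 of the 3 values shown sits. The measured step of an at least 3.2-fold higher number from compound 1 to compound 3 (0.51 log units; beyond the scatter) is therefore known only as a floor of its size. Compound 4 `CC#C[C@@]1(O)[C@@H](CO)O[C@@H](n2ccc(N)nc2=O)[C@@H]1O` differs from compound 3 by prop-1-yn-1-yl in place of propargyl on a saturated ring carbon. This undoes the move from but-1-yn-1-yl to propargyl behind an at least 3.2-fold higher number from compound 1 to compound 3 (0.51 log units; beyond the scatter) and brings compound 4 close to the pattern of compound 1, so compound 4 is expected to regain activity, an estimated step of an at least 2.3-fold lower number from compound 3 to compound 4 (0.36 log units; beyond the scatter). The estimate for compound 4 is 150000 nM, with a range from 60000 nM to 400000 nM.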

Compound 4, half-maximal inhibitory concentration: 14600 nM
Compound 4: middle estimate off by 10-fold (1.01 log units), on the high side; the whole stated range lies above it.
By their numbers in this assay, from the lowest: compound 4; then compound 1; then compound 2. At a limit, above all of these: compound 3.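

Compound 3 gives only a limit: the limit of > 350000 nM in this assay, at which 1 of the 4 values shown sits.

Joining the same atoms differently, as prop-1-yn-1-yl in place of propargyl, still gives an at least 23-fold lower number from compound 3 to compound 4 (1.37 log units; beyond the scatter) in this assay. On this ring carbon prop-1-yn-1-yl also outdoes ethyl, with an 18-fold lower number from compound 2 to compound 4 (1.25 log units; beyond the scatter), and the longer but-1-yn-1-yl, with a 7.4-fold lower number from compound 1 to compound 4 (0.87 log units; beyond the scatter), so chain length matters even with the triple bond in the same place. The compounds shown leave open whether the shorter ethynyl group would do better still on this ring carbon. They also do not tell why the place of the triple bond matters so much.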